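A few compounds are considered here, and "the series" means these few. Any claim that something is new, unique, unknown or untested is made for them only; others in the source may bear on it.

Working notes on the series. Three compounds have numbers in a functional assay on MDA-MB-435S cells (Homo sapiens) for antiproliferative activity, read by MTT assay, with a stated time of 72 h; a lower number here means a stronger inhibitor, a higher number a weaker inhibitor. Compound 1 `O=c1c(SC(=S)N2CCCC2)coc2ccc(Cl)cc12` gives 24000 nM, the highest of the three. Compound 2 `COc1ccc2occ(CSC(=S)N(C(C)C)C(C)C)c(=O)c2c1` gives 1800 nM, and compound 3 `CN1CCN(C(=S)SCc2coc3ccccc3c2=O)CC1` gives 2200 nM; both numbers sit beyond the scatter below that of compound 1. Compounds 2 and 3 differ from compound 1 in more than one place, so their gaps to compound 1 cannot be tied to a single change.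

Compound 4 `O=c1c(SC(=S)N2CCCCC2)coc2ccc(Cl)cc12` is not yet measured. It differs from compound 1 in one place: piperidin-1-yl in place of pyrrolidin-1-yl on a thiocarbonyl carbon. Among the compounds with values here, no pair of measured compounds isolates this change, so the expected size of the step rests on the change alone, a ring one member larger at the thiocarbonyl carbon. The step from compound 1 to compound 4 is expected to be small, at most a mild move toward a lower number, and quite possibly none beyond the scatter, as a 1.6-fold lower number from compound 1 to compound 4 (0.20 log units; within the scatter) expresses. For compound 4 the estimate is 15000 nM, within a range of 5000 nM to 45000 nM.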

Compound 4, half-maximal inhibitory concentration: 13300 nM
Beside the measured number, compound 4's estimate is 1.1-fold (0.05 log units) above it, within the range that was stated.
By their numbers in this assay, from the lowest: compounds 2 and 3 (each within the scatter of the next); then compounds 4 and 1 (each within the scatter of the next).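

In this assay, within the data shown here, the first pair that differs in one place gives a 1.8-fold lower number from compound 1 to compound 4 (0.26 log units; within the scatter), so piperidin-1-yl in place of pyrrolidin-1-yl on a thiocarbonyl carbon produces no step beyond the scatter on the core of compound 1. At this position, then, the two ring sizes cannot be told apart by this read-out. This single pair gives no reading of any other change at this position, and no information bearing on the reason for the result is available.

From the compounds shown here alone, it remains open whether morpholin-4-yl, or an open-chain group such as diethylamino, on the same thiocarbonyl carbon would also stay within the scatter of compound 1. The gaps between compound 1 and compounds 2 and 3 also remain untied to any single change.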